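Para substituent swaps on the pendant phenyl ring

A few compounds are considered here, and "the series" means these few. Any claim that something is new, unique, unknown or untested is made for them only; others in the source may bear on it.

Compound 1 `O=C(NC(=S)Nc1ccc(F)cc1)c1cn(-c2ccccc2)nc1-c1ccccc1`: 3500 nM
Compound 2 `O=C(NC(=S)Nc1ccc(F)cc1)c1cn(-c2ccccc2)nc1-c1ccc(F)cc1`: 3540 nM
Compound 3 `O=C(NC(=S)Nc1ccc(F)cc1)c1cn(-c2ccccc2)nc1-c1ccc(Cl)cc1`: 3980 nM

Of the compounds shown here, three have been measured in a functional assay on A549 cells (Homo sapiens) for inhibition, read by CCK-8 assay, with a stated time of 48 h; a higher number here means a weaker inhibitor, a lower number a stronger inhibitor. Compound 1 gives 3500 nM in this assay, compound 2 gives 3540 nM and compound 3 gives 3980 nM. Compound 3 carries the highest of the three numbers, but its distance to the other two is small: a 1.1-fold higher number from compound 1 to compound 3 (0.06 log units; within the scatter) and a 1.1-fold higher number from compound 2 to compound 3 (0.05 log units; within the scatter), both within the scatter, as is a 1.0-fold higher number from compound 1 to compound 2 (0.00 log units; within the scatter).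

Compound 4 `Cc1ccc(-c2nn(-c3ccccc3)cc2C(=O)NC(=S)Nc2ccc(F)cc2)cc1` has not yet been measured. It differs from compound 3 in one place: methyl in place of chloro on an aromatic carbon. Among the compounds with values here, the steps that bear on this change are the three already seen, all of which alter the same aromatic carbon of that ring, from hydrogen to fluoro, from hydrogen to chloro and from fluoro to chloro, and none of them moved the number beyond the scatter. On that basis the step to compound 4 is expected to be no larger, in either direction, so that a 1.0-fold lower number from compound 3 to compound 4 (0.02 log units; within the scatter) is the expected step in this assay. Compound 4 is therefore estimated at 3800 nM in this assay, with a range from 2000 nM to 7500 nM.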

Compound 4, half-maximal inhibitory concentration: 3420 nM
Estimate against measurement, compound 4: 1.1-fold (0.05 log units) above, within the range that was stated.
By their numbers in this assay, from the lowest: compounds 4, 1, 2 and 3 (each within the scatter of the next).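

Until now, only halogens had stood in place of hydrogen at this aromatic carbon, para to a large group; compound 4 shows that a methyl group can occupy it too, and in this assay the change again stays within the scatter, with a 1.2-fold lower number from compound 3 to compound 4 (0.07 log units; within the scatter), a 1.0-fold lower number from compound 2 to compound 4 (0.01 log units; within the scatter) and a 1.0-fold lower number from compound 1 to compound 4 (0.01 log units; within the scatter). The exchange of 4-chlorophenyl to 4-methylphenyl therefore gives no measurable separation, and hydrogen, fluoro, chloro and methyl at this carbon cannot be told apart in this read-out across compounds 1, 2, 3 and 4. No measured evidence is available that would explain this insensitivity.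

The compounds shown leave open whether this tolerance extends to groups of a different kind at the same carbon, such as an amine, a carboxylic acid or a longer chain, any of which might move the number beyond the scatter. They also leave open whether a substituent on another carbon of this ring, or a change elsewhere on the shared core, would matter more than these exchanges have.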